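The source may report more compounds than this note shows. Statements on the series, on what has been measured and on what is new or still open speak of the compounds shown alone.

Compound 2 `CC(=O)c1ccc(-c2cn3ccnc3c(-c3ccc4ncn(C5CCCCC5)c4c3)n2)cc1` gives 17.9% in a functional assay on PC-3 cells (Homo sapiens) for inhibition, read by sulforhodamine B assay, with a stated time of 48 h, tested at 10 uM (on this read-out lower numbers stand for less inhibition and higher numbers for more inhibition at the one concentration tested (going by the name of the read-out)), the lower of the two measured numbers; compound 1 `COc1ccc(-c2cn3ccnc3c(-c3ccc4ncn(C5CCCCC5)c4c3)n2)cc1` gives 95.2%. For the measured compounds named here, the only step seen so far, a number 77.3 percentage points lower from compound 1 to compound 2 (beyond the scatter), is the one that produced compound 2. Compound 3 `Clc1ccc(-c2cn3ccnc3c(-c3ccc4ncn(C5CCCCC5)c4c3)n2)cc1` differs from compound 2 by chloro in place of acetyl on an aromatic carbon. Going by the values given here, no measured step sets acetyl against chloro, so the direction is uncertain; because the acetyl coincided with the low number of compound 2 17.9%, its removal is expected to raise inhibition, though not necessarily to the level of compound 1. The estimate for compound 3 is 55%, ranging from 15% to 95%, an expected step of a number 37.1 percentage points higher from compound 2 to compound 3 (beyond the scatter).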

Compound 3, a percentage reported as inhibition, at one concentration (the size of the read-out at that concentration, not a potency): 24.6%
The estimate for compound 3 lay 30.4 percentage points above the measured number; the range from low to high includes it.
By their numbers in this assay, from the lowest: compounds 2 and 3 (each within the scatter of the next); then compound 1.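

With chloro in place of acetyl on this aromatic carbon, para to a large group, the read-out in this assay shows a number 6.7 percentage points higher from compound 2 to compound 3 (within the scatter), so the low number of compound 2 is not peculiar to acetyl. With chloro in place of methoxy, the same position shows a number 70.6 percentage points lower from compound 1 to compound 3 (beyond the scatter), which leaves compound 1 alone at the high end among these three. Nothing shown explains why methoxy stands apart from acetyl and chloro. Going by these compounds, whether an ethoxy, a hydroxyl or an amine at this position would match methoxy remains open.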